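Hydroxy in Place of Trifluoromethyl on Two Related Cores

The source may hold more compounds than are shown below. What is called first, only, known or untested is meant among the compounds shown, and "the series" means these compounds.

Of the compounds shown here, three have been measured in an ADME assay on HaCaT cells (Homo sapiens) for antiproliferative activity, read by MTT assay, with a stated time of 48 h; a lower number here means a stronger inhibitor, a higher number a weaker inhibitor. Compound 1 `O=C(/C=C\Nc1ccc(C(F)(F)F)cc1)c1cn(-c2ccccc2)nc1-c1ccccc1` reaches only a limit of the assay, > 50000 nM. Compound 2 `O=C(/C=C\Nc1ccc(O)cc1)c1cn(-c2ccccc2)nc1-c1ccccc1` gives 44600 nM. Compound 3 `COc1cc(-c2nn(-c3ccccc3)cc2C(=O)/C=C\Nc2ccc(C(F)(F)F)cc2)cc(OC)c1OC` likewise reaches only a limit, > 50000 nM. The change from compound 1 to compound 2 is hydroxy in place of trifluoromethyl on an aromatic carbon, and it produced an at least 1.1-fold lower number from compound 1 to compound 2 (0.04 log units; that floor lies within the scatter). The two cores differ by 3,4,5-trimethoxyphenyl in place of phenyl on an aromatic carbon, and the step there is a step that the two limits leave unreadable from compound 1 to compound 3; this reading is shaped by the limit of > 50000 nM in this assay, at which 2 of the 3 values shown sit.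

Compound 4 `COc1cc(-c2nn(-c3ccccc3)cc2C(=O)/C=C\Nc2ccc(O)cc2)cc(OC)c1OC` carries the same change on the core of compound 3, (hydroxy in place of trifluoromethyl on an aromatic carbon), with the surroundings of the place described in the same words as before.

Compound 4 is expected to give about 55000 nM in this assay, somewhere from 25000 nM to 150000 nM, and most likely to be reported as a limit rather than a number. The expected step that the limit leaves unreadable from compound 3 to compound 4 rests on the earlier at least 1.1-fold lower number from compound 1 to compound 2 (0.04 log units; that floor lies within the scatter), which stayed within the scatter, and on compound 3 standing at > 50000 nM.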

Compound 4, half-maximal inhibitory concentration: 17600 nM
Beside the measured number, compound 4's estimate is 3.1-fold (0.49 log units) above it, and the stated range ends above it.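

In this assay, hydroxy in place of trifluoromethyl on the core of compound 3 gives an at least 2.8-fold lower number from compound 3 to compound 4 (0.45 log units; beyond the scatter) and so leaves a readable step on this core, one that starts from a limit of the assay rather than from a number. Set beside the same change on the core of compound 1, the two results do not establish that the core alters the size of the step, and they do not show that the change carries over by a fixed amount: the same change on two cores in this assay, an at least 1.1-fold lower number (0.04 log units; that floor lies within the scatter) from compound 1 to compound 2 and an at least 2.8-fold lower number (0.45 log units; beyond the scatter) from compound 3 to compound 4; the limit leaves it open whether they differ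

Each step is known only as a floor, and the true size of neither can be read from the data, which is also why the comparison between the two cores stays unsettled: the limit of > 50000 nM in this assay, at which 2 of the 4 values shown sit.

The compounds shown leave open whether an amine or a carboxylic acid in the same place would lower the number as hydroxy does on the core of compound 3. They also leave open whether a methoxy group there would behave like hydroxy on either core, and whether the change would give a readable step on any core beyond these two.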